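This account rests on a few compounds, and the source may have more. Where it says the series, first, only, none or still open, it means among the compounds named here.

In an assay on CHO cells for displacement of a labelled ligand from adenosine receptor A3 (Homo sapiens), read by scintillation counting, with a stated time of 60 min (a lower number here means a stronger inhibitor, a higher number a weaker inhibitor), compound 1 `O=C(Nc1nc(-c2ccccc2)nc2cn(-c3ccccc3)nc12)c1ccco1` gives 24 nM. Among the measured compounds shown here, compound 2 `O=C(Nc1nc(-c2ccccc2)nc2cn(-c3ccccc3)nc12)c1ccncc1` differs from it only in the acyl group, and in this assay compound 2 gives 25 nM; the step of a 1.0-fold higher number from compound 1 to compound 2 (0.02 log units; within the scatter) lies within the scatter, so compound 2 stands level with compound 1, the only other compound measured, and neither can be called the stronger of the two.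

Compound 3 `Cc1nc(NC(=O)c2ccncc2)c2nn(-c3ccccc3)cc2n1` is drawn from compound 2 by a change at a different place: methyl in place of phenyl on an aromatic carbon. For the measured compounds named here, the one measured step, from compound 1 to compound 2, concerns the acyl group alone and says nothing about the group that leaves here, so there is no measured step that bears on this change. Going by the values given here, what is known is only that a six-membered aromatic ring of carbon is replaced by a single carbon; on that basis a weaker inhibitor is expected, and the expected step of an 8.0-fold higher number from compound 2 to compound 3 (0.90 log units; beyond the scatter) is set with a wide margin. For compound 3 in this assay the estimate is 200 nM, with a range from 30 nM to 2000 nM.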

Compound 3, inhibition constant: 5.2 nM
Compound 3: the middle estimate sits 38-fold (1.59 log units) above what was measured, and the stated range ends above it.
By their numbers in this assay, from the lowest: compound 3; then compounds 1 and 2 (each within the scatter of the next).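

In this assay, the step of a 4.8-fold lower number from compound 2 to compound 3 (0.68 log units; beyond the scatter) shows that, with the pyridin-4-yl acyl group held fixed, the phenyl on the aromatic carbon between two ring nitrogen atoms is not required for strong inhibition: methyl in its place gives the stronger inhibitor. Among the compounds shown here, the earlier pair differed only in the acyl group and showed no change beyond the scatter, so this is the first measured sign that the number responds to a change in the shared core's substituent at this position. Nothing shown here explains why removing the six-membered aromatic ring of carbon and leaving a single carbon gives this result.

The compounds shown leave open whether hydrogen, an ethyl or longer chain, or an amine on this carbon would give a lower or a higher number than methyl, so no trend can be drawn from just two groups. They also leave open whether methyl in place of phenyl gives a similar step when furan-2-yl, rather than pyridin-4-yl, sits on the carbonyl carbon.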